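Chain length at the ether position: a thioether analogue

The compounds below may be only part of what the source reports. "The series", "measured", "known", "first", "only" and "open" are said of these compounds alone.

Compound 1 `CCOc1nccnc1C1CN2CCC1CC2` stands lowest of the three measured compounds in a functional assay on A9L-m1 cells with A9 (Mus musculus) as the target (a lower number here means a smaller maximal response, a higher number a larger maximal response), where compound 1 gives 1%. Compound 2 `CCCCCCOc1nccnc1[C@@H]1CN2CCC1CC2` gives 33% in this assay, and compound 3 `CCCCCCCOc1nccnc1C1CN2CCC1CC2` gives 35%. For the measured compounds named here, the only single-point step among them is a number 34 percentage points higher from compound 1 to compound 3 (beyond the scatter), pentyl in place of hydrogen on a saturated chain carbon two bonds along the chain from the oxygen on the aromatic ring; compound 2 lies within the scatter of compound 3 and well above compound 1. Compound 4 `CCCCSc1nccnc1C1CN2CCC1CC2` differs from compound 1 by butylsulfanyl in place of ethoxy on an aromatic carbon. Going by the values given here, this change exchanges oxygen for sulfur and lengthens the chain, though by fewer atoms than the step to compound 3; no measured pair isolates the sulfur exchange on its own. The rise on chain growth in compound 3 and compound 2 makes an increase over compound 1 the likelier outcome, with wide uncertainty on its size. Compound 4 is expected to give 15% (range 0% to 35%), an expected step of a number 14 percentage points higher from compound 1 to compound 4 (beyond the scatter).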

Compound 4, largest response reached (reported as maximum), in percent of the reference or control that the assay uses: 5%
Compound 4: middle estimate off by 10 percentage points, on the high side; the measured number falls inside the stated range.
By their numbers in this assay, from the lowest: compounds 1 and 4 (each within the scatter of the next); then compounds 2 and 3 (each within the scatter of the next).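

In this assay the exchange of ethoxy for butylsulfanyl on this aromatic carbon gives a number 4 percentage points higher from compound 1 to compound 4 (within the scatter) and so does not move the maximal response. Lengthening the group at this position therefore does not raise the response in every case, since a number 34 percentage points higher from compound 1 to compound 3 (beyond the scatter) stands beyond the scatter while the step to the thioether does not. No measurement here accounts for this difference between the two steps.

The compounds shown leave open whether the flat result belongs to the sulfur or to a butyl chain that is still too short, as butoxy would compare directly with compound 4 and ethylsulfanyl directly with compound 1. As far as these compounds go, whether sulfur-linked chains can reach the level of compound 3 remains open too, and heptylsulfanyl would address this.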